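The compounds below may be only part of what the source reports. "The series", "measured", "known", "first", "only" and "open" are said of these compounds alone.

In a functional assay on BT-20 cells (Homo sapiens) for antiproliferative activity, read by trypan blue exclusion (on this read-out lower numbers stand for stronger inhibition and higher numbers for weaker inhibition), compound 1 `COc1ccc(CS(=O)(=O)/C=C/c2ccc(F)cc2OC)cc1` gives 15000 nM, compound 2 `COc1ccc(CS(=O)(=O)/C=C/c2c(OC)cccc2OC)cc1` gives 400 nM, and compound 3 `COc1ccc(CS(=O)(=O)/C=C/c2c(OC)cc(OC)cc2OC)cc1` gives 20 nM.

Compound 3 gives the lowest of the three numbers; compound 2 is its nearest neighbour and compound 1 lies furthest from it, both gaps beyond the scatter. Compound 4 `COc1ccc(CS(=O)(=O)/C=C/c2c(OC)cc(F)cc2OC)cc1` differs from compound 3 by fluoro in place of methoxy on an aromatic carbon. Among the measured compounds shown here, only one measured single-point step touches the same aromatic carbon, a 20-fold lower number from compound 2 to compound 3 (1.30 log units; beyond the scatter), which was large. Taking the methoxy away again, with a fluoro in its stead, is expected to undo much of that gain, so in this assay a step of a 15-fold higher number from compound 3 to compound 4 (1.18 log units; beyond the scatter) toward higher numbers is expected. Compound 4 is therefore estimated at 300 nM, with a range from 60 nM to 1500 nM.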

Compound 4, half-maximal inhibitory concentration: 750 nM
Compound 4: middle estimate off by 2.5-fold (0.40 log units), on the low side, and the stated range covers the measured number.
By their numbers in this assay, from the lowest: compound 3; then compounds 2 and 4 (each within the scatter of the next); then compound 1.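

At this carbon, para to a large group, fluoro does not take over from methoxy: the change gives a 38-fold higher number from compound 3 to compound 4 (1.57 log units; beyond the scatter), whereas fluoro in place of hydrogen gives only a 1.9-fold higher number from compound 2 to compound 4 (0.27 log units; within the scatter). The low number of compound 3 therefore goes with the methoxy itself, not with having any substituent at this carbon. Methoxy in place of hydrogen also lowers the number on a fluoro-bearing core, with a 20-fold lower number from compound 1 to compound 4 (1.30 log units; beyond the scatter), and the size of the step repeats: the same change on two cores in this assay, a 20-fold lower number (1.30 log units; beyond the scatter) from compound 2 to compound 3 and a 20-fold lower number (1.30 log units; beyond the scatter) from compound 1 to compound 4, 1.0-fold (0.00 log units) apart, within the scatter of two such steps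

The compounds shown leave open whether another group at this carbon, such as an ethoxy, a hydroxyl or an amine, would keep the low number of compound 3.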